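The source may report more compounds than this note shows. Statements on the series, on what has been measured and on what is new or still open speak of the compounds shown alone.

Compound 1 `Cc1ccc(-c2c(-c3ccc(F)cc3)nc(C(F)(F)F)n2CC[C@@H](O)C[C@@H](O)CC(=O)O)cc1` gives 750 nM in an assay on microsomes from liver for inhibition of 3-hydroxy-3-methylglutaryl-coenzyme A reductase (Rattus norvegicus) (a higher number here means a weaker inhibitor, a lower number a stronger inhibitor), and compound 2 `O=C(O)C[C@H](O)C[C@H](O)CCn1c(C(F)(F)F)nc(-c2ccc(F)cc2)c1-c1cccs1` gives 215 nM, the lower of the two numbers shown; the only measured step, a 3.5-fold lower number from compound 1 to compound 2 (0.54 log units; beyond the scatter), is an exchange of one aromatic group for another on the shared core. Compound 3 `O=C(O)C[C@H](O)C[C@H](O)CCn1c(C(F)(F)F)nc(-c2ccc(F)cc2)c1-c1cccnc1` carries the difference (pyridin-3-yl in place of thiophen-2-yl on an aromatic carbon). Going by the values given here, that measured step is the only guide, and it was modest, so compound 3 is expected to stay near compound 2, with a step of a 1.4-fold higher number from compound 2 to compound 3 (0.14 log units; within the scatter) in this assay. The estimate for compound 3 is 300 nM, within a range of 100 nM to 900 nM.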

Compound 3, half-maximal inhibitory concentration: > 1000 nM
Compound 3 ended at the assay's limit; the forecaster's own chance of this, stated with the estimate: 5%; at least 3.3-fold (0.52 log units) between middle value and limit.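

At this position on the shared core, the choice of aromatic ring clearly matters: thiophen-2-yl and pyridin-3-yl each count one hydrogen-bond acceptor, yet the exchange gives an at least 4.6-fold higher number from compound 2 to compound 3 (0.66 log units; beyond the scatter). Against 4-methylphenyl, the exchange gives an at least 1.3-fold higher number from compound 1 to compound 3 (0.12 log units; that floor lies within the scatter), so compound 3 cannot be firmly separated from compound 1. The reading for compound 3 is a limit of the assay, not a number: the limit of > 1000 nM in this assay, at which 1 of the 3 values shown sits.

Where an unsubstituted phenyl, a thiophen-3-yl or an amine-bearing pyridine would fall at this position remains open. Going by these compounds, the true value of compound 3 also remains open.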